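Chloro for Bromo: Predicting Compound 4's Cytotoxicity

The compounds below may be only part of what the source reports. "The series", "measured", "known", "first", "only" and "open" are said of these compounds alone.

Of the compounds shown here, three sharing one core have been tested in a functional assay on ZR-75-1 cells (Homo sapiens) for cytotoxicity; a lower number here means that less compound is needed, a higher number that more compound is needed for the effect. Compound 1 `CCC[C@@H](OC(C)=O)C1=C(Br)/C(=C/Br)OC1=O` gives 1.6 ug/mL and compound 2 `CCC[C@@H](O)C1=C(Br)/C(=C/I)OC1=O` gives 0.3 ug/mL. Compound 3 `CCC[C@@H](O)C1=C(Br)/C(=C/Br)OC1=O` reaches only the limit of the assay, < 0.1 ug/mL, so no exact number is known for it. Two steps lead to compound 3: an at least 16-fold lower number from compound 1 to compound 3 (1.20 log units; beyond the scatter) and an at least 3.0-fold lower number from compound 2 to compound 3 (0.47 log units; beyond the scatter). Compound 4 `CCC[C@@H](O)C1=C(Br)/C(=C/Cl)OC1=O` has not yet been measured. It differs from compound 3 in one place: chloro in place of bromo on a double-bonded chain carbon bound to a double-bonded ring carbon. Among the measured compounds shown here, only the step between compound 2 and compound 3 bears on this change, as it too alters the halogen on a double-bonded chain carbon bound to a double-bonded ring carbon; there the swap of iodo for bromo lowered the number by at least a modest amount. Whether moving on to chloro continues that trend or reverses it cannot be read from a single step, and compound 3 itself sits at the limit (the limit of < 0.1 ug/mL in this assay, at which 1 of the 3 values shown sits). Compound 4 is therefore expected to land close to that limit, a step of a number no lower from compound 3 to compound 4 (the limit leaves the size open). The estimated value of compound 4 in this assay is 0.1 ug/mL, within 0.03 ug/mL to 0.4 ug/mL.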

Compound 4, concentration for half-maximal effect: 0.4 ug/mL
For compound 4 the middle estimate is 4.0-fold (0.60 log units) below the measured one; the range from low to high includes it.
By their numbers in this assay, from the lowest: compounds 2 and 4 (each within the scatter of the next); then compound 1. At a limit, below all of these: compound 3.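

In this assay, among the compounds shown here, compound 3, with bromo on the double-bonded chain carbon bound to a double-bonded ring carbon, remains the only compound at a limit: the limit of < 0.1 ug/mL in this assay, at which 1 of the 4 values shown sits. Chloro in place of bromo gives an at least 4.0-fold higher number from compound 3 to compound 4 (0.60 log units; beyond the scatter), so the lower number seen on going from iodo to bromo does not carry on to chloro, and bromo now stands apart from both of the other halogens at this place. Chloro in place of iodo gives a 1.3-fold higher number from compound 2 to compound 4 (0.12 log units; within the scatter), so these two halogens cannot be told apart here.

From the compounds shown here alone, how far bromo stands from chloro and iodo stays open, since compound 3 gives only a limit. Also open, going by these compounds, are how fluoro or a methyl group at this place would compare, and whether an acetyl on the oxygen would raise the number as much alongside chloro as it does alongside bromo.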